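The source may report more compounds than this note shows. Statements on the series, on what has been measured and on what is new or still open speak of the compounds shown alone.

In a physicochemical assay for solubility, read by HPLC, in phosphate buffer, measured as thermodynamic solubility, with a stated time of 24 h, at pH 7.4 (a lower number here means a less soluble compound, a higher number a more soluble compound), compound 2 `C[C@@H]1CN([C@@H](C)CO)C(=O)c2cccc(NC(=O)Nc3cccc4ncccc34)c2O[C@H]1CN(C)S(=O)(=O)c1ccc2c(c1)OCCO2` stands at the higher of the two numbers measured, giving 139000 nM. Among the measured compounds shown here, its only neighbour, compound 1 `C[C@@H]1CN([C@@H](C)CO)C(=O)c2cccc(NC(=O)Nc3nccc4ccccc34)c2O[C@H]1CN(C)S(=O)(=O)c1ccc2c(c1)OCCO2`, gives 700 nM in this assay, and the single measured step, a 200-fold higher number from compound 1 to compound 2 (2.30 log units; beyond the scatter), is large. Compound 3 `C[C@@H]1CN([C@@H](C)CO)C(=O)c2cccc(NC(=O)Nc3cccc4ccncc34)c2O[C@H]1CN(C)S(=O)(=O)c1ccc2c(c1)OCCO2` differs from compound 2 by isoquinolin-8-yl in place of quinolin-5-yl on an amide-type nitrogen. For the measured compounds named here, no measured step covers this exchange: the step from compound 1 to compound 2 swaps an isoquinolin-1-yl for a quinolin-5-yl, whereas compound 3 keeps an isoquinoline and shifts the point of attachment, so that step bears on the present change only loosely. Given that the one known rearrangement of this group moved solubility a long way, the author expects the step of a 4.6-fold lower number from compound 2 to compound 3 (0.67 log units; beyond the scatter) to be a drop beyond the scatter but less than the full distance back to compound 1. Compound 3 is therefore estimated at 30000 nM, within a range from 3000 nM to 150000 nM.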

Compound 3, solubility: 101000 nM
The estimate for compound 3 lay 3.4-fold (0.53 log units) below the measured number; the range from low to high includes it.
By their numbers in this assay, from the lowest: compound 1; then compounds 3 and 2 (each within the scatter of the next).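

In this assay the exchange of quinolin-5-yl for isoquinolin-8-yl on the amide-type nitrogen gives a 1.4-fold lower number from compound 2 to compound 3 (0.14 log units; within the scatter) and so separates compound 3 from compound 2 by no more than the scatter. The isoquinolin-1-yl and isoquinolin-8-yl groups have the same atoms joined differently, yet they differ by a 140-fold higher number from compound 1 to compound 3 (2.16 log units; beyond the scatter), a large step. The low number of compound 1 therefore does not go with the isoquinoline name as such, and among these three compounds only the isoquinolin-1-yl group stands apart.

The compounds shown leave open whether a naphthyl or pyridinyl group on the same amide-type nitrogen, or an amine on the isoquinolin-8-yl group, would stay with compound 2 and compound 3 or fall towards compound 1. No supporting measurement accompanies these results to explain the size of either step.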